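The source may report more compounds than this note shows. Statements on the series, on what has been measured and on what is new or still open speak of the compounds shown alone.

Measured in a functional assay on A549 cells (Homo sapiens) for inhibition, read by MTT assay, with a stated time of 72 h; on this read-out higher numbers stand for weaker inhibition and lower numbers for stronger inhibition:

Compound 1 `COc1cc(/C=C/C(=O)c2c(OC)cc(O)c(CC=C(C)C)c2O)ccc1O`: 11800 nM
Compound 2 `COc1ccc(/C=C/C(=O)c2c(OC)cc(O)c(CC=C(C)C)c2O)cc1OC`: 15700 nM
Compound 3 `COc1cc(OC)c(C(=O)/C=C/c2ccc(O)c(O)c2)c(OC)c1`: 8200 nM

All three numbers lie close together: compound 3 gives the lowest, but its gap to compound 1 and to compound 2 stays within the usual scatter, so no order among them can be read from these values. Compound 2 differs from compound 1 by a single change, (methyl in place of hydrogen on an oxygen on an aromatic ring), and that change made a step of a 1.3-fold higher number from compound 1 to compound 2 (0.12 log units; within the scatter).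

The unmeasured compound 4 `COc1cc(OC)c(C(=O)/C=C/c2ccc(O)c(OC)c2)c(OC)c1` differs from compound 3 by methyl in place of hydrogen on an oxygen on an aromatic ring, the same change at the same kind of place. How the core of compound 3 differs from the core of compound 1 is not broken down here.

Within the data shown here, because the one earlier example of this change gave a 1.3-fold higher number from compound 1 to compound 2 (0.12 log units; within the scatter), a step of about the same small size is expected from compound 3 to compound 4 in this assay, namely a 1.3-fold higher number from compound 3 to compound 4 (0.11 log units; within the scatter). Compound 4 is therefore estimated at 10500 nM, most likely between 4500 nM and 25000 nM.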

Compound 4, half-maximal inhibitory concentration: 43800 nM
Estimate against measurement, compound 4: 4.2-fold (0.62 log units) below, outside the stated range (above it).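

In this assay, replacing hydroxy with methoxy gave a 5.3-fold higher number from compound 3 to compound 4 (0.73 log units; beyond the scatter), a clear weakening of inhibition, whereas the same change on the core of compound 1 gave a 1.3-fold higher number from compound 1 to compound 2 (0.12 log units; within the scatter). The effect of this change therefore did not carry over unchanged from one core to the other, and the two steps differ by more than repeated measurements would normally explain: the same change on two cores in this assay, a 1.3-fold higher number (0.12 log units; within the scatter) from compound 1 to compound 2 and a 5.3-fold higher number (0.73 log units; beyond the scatter) from compound 3 to compound 4, 4.0-fold (0.60 log units) apart, beyond the scatter of two such steps. This does not show why the cores respond differently, as the difference between the core of compound 1 and the core of compound 3 is not broken down here, and two examples give no rule for other cores.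

The compounds shown leave open what an ethyl group or a longer chain would do in place of the methyl on this oxygen. They also leave open whether the larger step is peculiar to the core of compound 3, which a further core carrying both the hydroxy and the methoxy forms could help to settle.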